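Moving from compound 3 to a longer amine chain

The compounds below may be only part of what the source reports. "The series", "measured", "known", "first", "only" and "open" are said of these compounds alone.

- compound 1 `CCCCNC(=O)Nc1cccc2c1CN(C)CC2c1ccccc1`: about 40 mg/kg
- compound 2 `CCNCC(=O)Nc1cccc2c1CN(C)CC2c1ccccc1`: 47 mg/kg
- compound 3 `CC(C)NCC(=O)Nc1cccc2c1CN(C)CC2c1ccccc1`: 14 mg/kg

In a functional assay on the whole organism for inhibition, with Mus musculus as the target (a higher number here means that more compound is needed for the effect, a lower number that less compound is needed), compound 3 gives 14 mg/kg, the lowest of the three numbers, so less of it is needed than of compound 1 or compound 2. The next compound, compound 4 `CCCCNCCC(=O)Nc1cccc2c1CN(C)CC2c1ccccc1`, has not been measured yet. It keeps the shared core but has (butylamino)methyl in place of isopropylamino on a saturated chain carbon bound to a carbonyl carbon.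

For the measured compounds named here, two measured steps bear on this change. Both end at compound 3 and both are modest: a 3.4-fold lower number from compound 2 to compound 3 (0.53 log units; beyond the scatter) and a 2.9-fold lower number from compound 1 to compound 3 (0.46 log units; beyond the scatter). The isopropylamino group therefore appears only in the compound with the lowest number, while compound 1 and compound 2 sit close together, with a 1.2-fold higher number from compound 1 to compound 2 (0.07 log units; within the scatter). Removing that group may give back a similar amount. Going by the values given here, no measured compound carries the 2-(butylamino)ethyl group, so this reading is uncertain and the range must stay wide.

A modest rise in this assay is expected, an estimated 2.5-fold higher number from compound 3 to compound 4 (0.40 log units; beyond the scatter). For compound 4 the estimated value is 35 mg/kg, with an expected range of 14 mg/kg to 85 mg/kg.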

Compound 4, dose for half-maximal effect: about 46 mg/kg
Beside the measured number, compound 4's estimate is 1.3-fold (0.12 log units) below it, and the stated range covers the measured number.
By their numbers in this assay, from the lowest: compound 3; then compounds 1, 4 and 2 (each within the scatter of the next).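

In this assay the step of a 3.3-fold higher number from compound 3 to compound 4 (0.52 log units; beyond the scatter) is modest but beyond the scatter, so the low number of compound 3 does not survive when (butylamino)methyl replaces isopropylamino on this saturated chain carbon bound to a carbonyl carbon. The new compound instead joins the other two, with a 1.0-fold lower number from compound 2 to compound 4 (0.01 log units; within the scatter) for (butylamino)methyl in place of ethylamino and a 1.2-fold higher number from compound 1 to compound 4 (0.06 log units; within the scatter) for 2-(butylamino)ethyl in place of butylamino on a carbonyl carbon, both within the scatter, so in these three compounds neither the longer amine chain nor the added chain carbon changes the number in a way that can be read, and compound 3 alone stands apart from the rest. Nothing given here explains why the isopropylamino compound stands apart.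

Still open, going by these compounds, is whether the low number belongs to isopropylamino itself or would also appear with another amine on this chain, such as tert-butylamino or a ring amine like pyrrolidine. On these data alone, it is equally open whether a 2-(isopropylamino)ethyl group would keep the number of compound 3 or fall in with the others.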